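A few compounds are considered here, and "the series" means these few. Any claim that something is new, unique, unknown or untested is made for them only; others in the source may bear on it.

Values in a functional assay on A549 cells (Homo sapiens) for antiproliferative activity, read by MTT assay; a lower number here means a stronger inhibitor, a higher number a weaker inhibitor:
- compound 1 `COc1ccc(-n2cc(COc3ccc(/C=C/C(=O)c4cc5c(cc4O)OC(C)(C)CC5)cc3)nn2)c([N+](=O)[O-])c1` gives 99500 nM
- compound 2 `CCc1ccccc1-n1cc(COc2ccc(/C=C/C(=O)c3cc4c(cc3O)OC(C)(C)CC4)cc2)nn1` gives 137000 nM
- compound 3 `COc1ccc(-n2cc(COc3ccc(/C=C/C(=O)c4ccc5c(c4O)CCC(C)(C)O5)cc3)nn2)c([N+](=O)[O-])c1` gives "not active" (no number reported)

Compound 2 stands within the scatter of compound 1 on these numbers, and compound 3 offers no number to compare. Going by the values given here, the change to compound 4 `CCCCCCCCn1cc(COc2ccc(/C=C/C(=O)c3cc4c(cc3O)OC(C)(C)CC4)cc2)nn1` is octyl in place of 2-ethylphenyl on an aromatic nitrogen and the one measured step at that nitrogen is a 1.4-fold higher number from compound 1 to compound 2 (0.14 log units; within the scatter) which stays within the scatter. Among the compounds with values here, that step keeps a ring in the group, so no measured step shows the loss of the ring. In this assay no step beyond the scatter is expected, and the estimated step is a 1.5-fold lower number from compound 2 to compound 4 (0.18 log units; within the scatter) with wide uncertainty. Compound 4 is estimated at 90000 nM with a range from 30000 nM to 200000 nM and a report without a number remains possible.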

Compound 4, half-maximal inhibitory concentration: 50800 nM
Compound 4: the middle estimate sits 1.8-fold (0.25 log units) above what was measured; the range from low to high includes it.
By their numbers in this assay, from the lowest: compounds 4, 1 and 2 (each within the scatter of the next, the first and the last beyond it).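

In this assay, going by these compounds alone, octyl on the aromatic nitrogen gives a 2.7-fold lower number from compound 2 to compound 4 (0.43 log units; beyond the scatter), the first step at this position beyond the scatter and the first measured loss of the ring from the group. Set against 4-methoxy-2-nitrophenyl, octyl gives a 2.0-fold lower number from compound 1 to compound 4 (0.29 log units; within the scatter), so it is separated from 2-ethylphenyl only. No measurement bears on a cause for this step.

Still open, going by these compounds, is whether a shorter chain such as butyl, a longer chain such as dodecyl, or an amine carried on the chain would shift the number further at this nitrogen.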